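A Branched Chain on the Sulfonamide Nitrogen

The source may report more compounds than this note shows. Statements on the series, on what has been measured and on what is new or still open speak of the compounds shown alone.

In a physicochemical assay for solubility, with a stated time of 24 h, tested at 30 mg/mL (a higher number here means a more soluble compound, a lower number a less soluble compound), compound 3 (`Cc1cc(COc2ccc(S(=O)(=O)NCCC(=O)NO)cc2)c2ccccc2n1`) reads 4100000 nM and stands second among the three measured compounds. Compound 2 (`CC(=O)N1CC2(C1)CC(NS(=O)(=O)c1ccc(OCc3cc(C)nc4ccccc34)cc1)(C(=O)NO)C2`) gives the highest number at 17000000 nM and compound 1 (`CC(=O)N1CC(CC(=O)NO)(NS(=O)(=O)c2ccc(OCc3cc(C)nc4ccccc34)cc2)C1`) gives the lowest at 800000 nM with both gaps to compound 3 beyond the scatter.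

The next compound is compound 4 (`Cc1cc(COc2ccc(S(=O)(=O)NC(C)(C)CC(=O)NO)cc2)c2ccccc2n1`). Its change from compound 3 is a group of 8 heavy atoms (5 carbon, 1 nitrogen, 2 oxygen; no ring) in place of a group of 6 heavy atoms (3 carbon, 1 nitrogen, 2 oxygen; no ring), on a sulfonamide nitrogen and it replaces the 2-(hydroxycarbamoyl)ethyl group, while the rest of the structure stays the same. Within the data shown here, no two measured compounds differ in one place alone, so the data give no direct measure of such a change. The closest anchor is compound 3 at 4100000 nM and the expectation stays near it, with a slight downward lean that is only a judgement. The expected step is a 1.6-fold lower number from compound 3 to compound 4 (0.21 log units; within the scatter) and it is not expected to lie beyond the scatter. Compound 4 is estimated at 2500000 nM with an expected range from 800000 nM to 8000000 nM in this assay once measured.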

Compound 4, solubility: 1600000 nM
Compound 4: middle estimate off by 1.6-fold (0.19 log units), on the high side, within the range that was stated.
By their numbers in this assay, from the lowest: compounds 1 and 4 (each within the scatter of the next); then compound 3; then compound 2.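

Among these compounds, at this place, on a sulfonamide nitrogen, the earlier compounds offered no direct comparison, but this assay now gives one: replacing the 2-(hydroxycarbamoyl)ethyl group with the group of 8 heavy atoms gives a 2.6-fold lower number from compound 3 to compound 4 (0.41 log units; beyond the scatter). The two groups have the same counts of nitrogen and oxygen atoms, hydrogen-bond donors and acceptors, and neither has a ring or a net charge, so this step accompanies a change in which the counted difference lies in the carbon atoms. Nothing available explains why the number falls with this change.

The compounds shown leave open whether a longer chain at this place would lower the number further. They also leave open how an amine or a carboxylic acid on the chain would compare with either group.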